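The source may report more compounds than this note shows. Statements on the series, on what has been measured and on what is new or still open speak of the compounds shown alone.

Measured in an ADME assay on MT4 cells (Homo sapiens) for cytotoxicity, read by MTT assay; on this read-out lower numbers stand for higher toxicity in this test and higher numbers for lower toxicity in this test:
- Compound 1 `Cc1ccccc1C(=O)N(C(=S)OCCN1C(=O)c2ccccc2C1=O)c1ccc(Cl)cc1`: 21000 nM
- Compound 2 `O=C1c2ccccc2C(=O)N1CCOC(=S)N(C(=O)c1ccc(C(F)(F)F)cc1)c1ccc(Cl)cc1`: 10000 nM
- Compound 3 `O=C1c2ccccc2C(=O)N1CCOC(=S)N(C(=O)c1ccc([N+](=O)[O-])cc1)c1ccc(Cl)cc1`: > 100000 nM (a limit)

Compound 3 reads > 100000 nM, which is a limit of the assay and not a number.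

Compound 4 `O=C1c2ccccc2C(=O)N1CCOC(=S)N(C(=O)c1cc(F)ccc1F)c1ccc(Cl)cc1` keeps the shared core and changes one group: 2,5-difluorophenyl in place of 4-nitrophenyl on a carbonyl carbon. In words, 2,5-difluorophenyl stands in place of 4-nitrophenyl on a carbonyl carbon.

The measured compounds differ from one another at this same place. Bringing in 4-nitrophenyl gave an at least 4.7-fold higher number from compound 1 to compound 3 (0.67 log units; beyond the scatter) and an at least 10-fold higher number from compound 2 to compound 3 (1.00 log units; beyond the scatter). The swap that did not involve 4-nitrophenyl gave a 2.1-fold lower number from compound 1 to compound 2 (0.32 log units; beyond the scatter), a smaller move. Compound 4 gives up 4-nitrophenyl, so it is expected to read closer to the two compounds without that group, a clear step to a lower number in this assay. With only a limit as the starting point, the size of that step stays loose.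

The expected step is an at least 4.0-fold lower number from compound 3 to compound 4 (0.60 log units; beyond the scatter).

For compound 4 the estimated value is 25000 nM, with an expected range of 7000 nM to 100000 nM.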

Compound 4, half-maximal cytotoxic concentration: 54000 nM
Compound 4: the middle estimate sits 2.2-fold (0.33 log units) below what was measured; measured number inside the range.
By their numbers in this assay, from the lowest: compound 2; then compound 1; then compound 4. At a limit, above all of these: compound 3.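

In this assay, a high reading at this place does not need 4-nitrophenyl: 2,5-difluorophenyl on the carbonyl carbon gives a 5.4-fold higher number from compound 2 to compound 4 (0.73 log units; beyond the scatter) and a 2.6-fold higher number from compound 1 to compound 4 (0.41 log units; beyond the scatter) as well, the highest of the three readings that are true numbers. The step of an at least 1.8-fold lower number from compound 3 to compound 4 (0.26 log units; that floor lies within the scatter) has a floor that lies within the scatter, so it does not settle the order of that pair. Compound 3 stays a limit and not a number: the limit of > 100000 nM in this assay, at which 1 of the 4 values shown sits.

As far as these compounds go, how far apart the two highest compounds truly lie therefore stays open. All the groups shown at this place are substituted phenyl rings, so what a longer chain, or a phenyl ring carrying an amine or a carboxylic acid, would do to this reading also stays open.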